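Trimming one methyl from the lactam of compound 3

The source may report more compounds than this note shows. Statements on the series, on what has been measured and on what is new or still open speak of the compounds shown alone.

Of the compounds shown here, three sharing one core have been measured in a physicochemical assay for solubility, read by LC-MS, in phosphate buffer, with a stated time of 24 h, at pH 7.4; a lower number here means a less soluble compound, a higher number a more soluble compound. Compound 1 `O=C1CCCN1c1cnc(NCc2c(F)ccc3c2CCO3)n2cnnc12` gives 640000 nM in this assay, compound 2 `CNC(=O)c1ccc(-c2cnc(NCc3c(F)ccc4c3CCO4)c3cn[nH]c(=O)c23)c(C)n1` gives 19000 nM, and compound 3 `CC1(C)CC(=O)N(c2cnc(NCc3c(F)ccc4c3CCO4)n3cnnc23)C1` gives 57000 nM. On these numbers compound 3 stands second highest of the three: its nearest neighbour is compound 2, which sits lower, and the furthest is compound 1, which sits higher; both gaps lie beyond the scatter.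

The unmeasured compound 4 `C[C@@H]1CC(=O)N(c2cnc(NCc3c(F)ccc4c3CCO4)n3cnnc23)C1` differs from compound 3 in one place: 4-methyl-2-oxopyrrolidin-1-yl in place of 4,4-dimethyl-2-oxopyrrolidin-1-yl on an aromatic carbon.

Among the measured compounds shown here, only one measured step bears on this change. It is the step of an 11-fold lower number from compound 1 to compound 3 (1.05 log units; beyond the scatter), in which the 4,4-dimethyl-2-oxopyrrolidin-1-yl replaced the 2-oxopyrrolidin-1-yl on the same aromatic carbon. Compound 4 carries a 4-methyl-2-oxopyrrolidin-1-yl, which sits between those two groups in what it contains, so the expected movement in this assay is a reversal of part of that large step, upward from compound 3 and beyond the scatter, but not back to the number of compound 1. The step from compound 3 to compound 4 is therefore estimated as a 2.8-fold higher number from compound 3 to compound 4 (0.45 log units; beyond the scatter). Compound 4 is expected to give about 160000 nM, within a range from 65000 nM to 400000 nM.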

Compound 4, solubility: 130000 nM
Compound 4: middle estimate off by 1.2-fold (0.09 log units), on the high side; the measured number falls inside the stated range.
By their numbers in this assay, from the lowest: compound 2; then compound 3; then compound 4; then compound 1.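

Among the compounds shown here, compound 4 splits the single large step from compound 1 to compound 3 into two parts at the same saturated ring carbon of the 2-oxopyrrolidin-1-yl group. In this assay the first methyl alone brings a 4.9-fold lower number from compound 1 to compound 4 (0.69 log units; beyond the scatter) and the second methyl still matters, as its removal gives a 2.3-fold higher number from compound 3 to compound 4 (0.36 log units; beyond the scatter) and so neither methyl is silent at this position. Among these three compounds, which differ only in this group, the number falls with each added methyl and none goes against that order, though nothing shown accounts for the movement.

The compounds shown leave open whether the opposite stereocentre in the 4-methyl-2-oxopyrrolidin-1-yl group would give a number like that of compound 4, since only one defined stereocentre appears here. They also leave open how a hydroxyl group, an amine or a fluorine on that saturated ring carbon would compare with the hydrogen of compound 1 and the methyl of compound 4 in this assay and whether the order seen with methyl would hold for them.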